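The source may report more compounds than this note shows. Statements on the series, on what has been measured and on what is new or still open speak of the compounds shown alone.

Measured so far:
compound 1 `OC[C@@]1(O)CO[C@@H](n2cnc3c(NCc4cccc(Cl)c4)ncnc32)[C@@H]1O`: 10%
compound 2 `OC[C@]1(O)CO[C@@H](n2cnc3c(NCc4cccc(I)c4)ncnc32)[C@@H]1O`: 35%

In an assay on CHO cells for displacement of a labelled ligand from adenosine receptor A1 (Homo sapiens), tested at 10 uM (a lower number here means less inhibition, a higher number more inhibition at the concentration tested (going by the name of the read-out)), compound 2 gives 35%, the higher of the two numbers; compound 1 gives 10%, a gap beyond the scatter. Compound 3 `OC[C@]1(O)CO[C@@H](n2cnc3c(NCc4cccc(Cl)c4)ncnc32)[C@@H]1O` has not yet been measured in this assay. It differs from compound 2 by chloro in place of iodo on an aromatic carbon. Among the measured compounds shown here, no step between measured compounds is at hand to size this change directly. Compound 1, which also carries chloro, gives 10%, so a fall beyond the scatter is expected. Compound 3 is expected to give 15%, in the range 0% to 35%. The expected step is a number 20 percentage points lower from compound 2 to compound 3 (beyond the scatter), a loss of inhibition.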

Compound 3, a percentage reported as inhibition, at one concentration (the size of the read-out at that concentration, not a potency): 19%
Compound 3: the middle estimate sits 4 percentage points below what was measured; the range from low to high includes it.
By their numbers in this assay, from the lowest: compounds 1 and 3 (each within the scatter of the next); then compound 2.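

In this assay, chloro in place of iodo on this aromatic carbon gives a number 16 percentage points lower from compound 2 to compound 3 (beyond the scatter) as the first direct size of this change, a modest one. The configuration at the saturated ring carbon gives a number 9 percentage points higher from compound 1 to compound 3 (within the scatter) as its only comparison, so no effect of that stereocentre can be read here, and the comparison isolates that one element: the fact that compounds 1 and 3 differ only in the configuration as drawn

Open, going by these compounds, is whether the step from iodo to chloro carries over to the configuration of compound 1. Also open, on these data alone, is how a methoxy group or a carboxylic acid would read at this aromatic carbon.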